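Series notes: phenyl in place of benzyl

A few compounds are considered here, and "the series" means these few. Any claim that something is new, unique, unknown or untested is made for them only; others in the source may bear on it.

Measured compounds:
- compound 1 `CC1CCN(C(=O)c2cccc(N/C(=N/O)c3ccc4occc4c3)c2)CC1`; in an assay on tissue (HeLa cells) for inhibition of Indoleamine 2,3-dioxygenase 1 (Homo sapiens), read by spectrophotometry (on this read-out higher numbers stand for weaker inhibition and lower numbers for stronger inhibition), compound 1 gives > 30000 nM, a limit of the assay and not a number.
- compound 2 `O/N=C(/Nc1cccc(Cc2ccccc2)c1)c1ccc2occc2c1`; in this assay compound 2 gives > 30000 nM, again a limit of the assay and not a number.

Both measured values sit at the same boundary: the limit of > 30000 nM in this assay, at which 2 of the 2 values shown sit. Among the compounds with values here, the one step between them, a step that the two limits leave unreadable from compound 1 to compound 2, therefore has no readable size, and compound 2 stands at the limit in this assay with no numerical position of its own.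

Compound 3 `O/N=C(/Nc1cccc(-c2ccccc2)c1)c1ccc2occc2c1` differs from compound 2 by phenyl in place of benzyl on an aromatic carbon. Within the data shown here, no measured step bears on this change in a readable way, since the step from compound 1 to compound 2 is hidden by the two limits. With compound 2 sitting at the limit, compound 3 is expected to remain there as well, with a number no higher from compound 2 to compound 3 (the limit leaves the size open) expected to be nothing beyond the scatter. The estimate for compound 3 in this assay is 30000 nM, within 8000 nM to 100000 nM, most likely reported again only as a limit.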

Compound 3, half-maximal inhibitory concentration: 11900 nM
For compound 3 the middle estimate is 2.5-fold (0.40 log units) above the measured one; the measured number falls inside the stated range.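

In this assay, the place on the aromatic ring that carries these groups now gives a readable number: phenyl in place of benzyl yields an at least 2.5-fold lower number from compound 2 to compound 3 (0.40 log units; beyond the scatter), and phenyl in place of (4-methylpiperidin-1-yl)carbonyl yields an at least 2.5-fold lower number from compound 1 to compound 3 (0.40 log units; beyond the scatter). Neither compound 1 nor compound 2 showed that a change at this place could bring the read-out off the limit. Both steps are bounds and not full sizes: the limit of > 30000 nM in this assay, at which 2 of the 3 values shown sit.

As far as these compounds go, how far compound 3 truly lies from compound 1 and compound 2 remains open. Also open, from the compounds shown here alone, is whether a cyclohexyl, a pyridyl or a carboxylic acid at the same place would give a lower number, the same number or a return to the limit.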